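From propyl to isopropyl on the chain of compound 3

The source may report more compounds than this note shows. Statements on the series, on what has been measured and on what is new or still open speak of the compounds shown alone.

Measured in a functional assay on MCF7 cells (Homo sapiens) for antiproliferative activity, read by MTT assay, with a stated time of 72 h; a lower number here means a stronger inhibitor, a higher number a weaker inhibitor:
Compound 1 `CC(C)/C=C/C(=O)Nc1cccc(Oc2nc(Nc3ccn(C)n3)nc3c2CSCC3)c1` gives > 50000 nM (a limit)
Compound 2 `COc1cccc(Nc2nc3c(c(Oc4cccc(NC(=O)/C=C/C(C)C)c4)n2)CSCC3)c1` gives 21800 nM
Compound 3 `CCC/C=C/C(=O)Nc1cccc(Oc2nc(Nc3ccc(OC)nc3)nc3c2CSCC3)c1` gives 26800 nM

Compound 1 stands at the limit of > 50000 nM in this assay, at which 1 of the 3 values shown sits, and gives no number. In this assay compound 3 at 26800 nM lies within the scatter of compound 2 at 21800 nM, so neither can be ranked over the other.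

Compound 4 `COc1ccc(Nc2nc3c(c(Oc4cccc(NC(=O)/C=C/C(C)C)c4)n2)CSCC3)cn1` has not yet been measured. It departs from compound 3 by a single exchange, (isopropyl in place of propyl on a double-bonded chain carbon bound to a double-bonded chain carbon), which turns the pent-1-en-1-yl chain into 3-methylbut-1-en-1-yl. The two compounds have the same atoms, joined differently.

For the measured compounds named here, no measured step makes this exchange. Going by the values given here, the only step available, an at least 2.2-fold lower number from compound 1 to compound 2 (0.36 log units; beyond the scatter), puts 3-methoxyphenyl in place of 1-methyl-1H-pyrazol-3-yl on a nitrogen on an aromatic ring, so its size does not carry over to the chain. With compound 3 at 26800 nM as the starting point, no change beyond the scatter is expected in this assay. The expected step is a 1.1-fold lower number from compound 3 to compound 4 (0.03 log units; within the scatter). For compound 4 the estimate is 25000 nM, with an expected range from 12000 nM to 50000 nM.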

Compound 4, half-maximal inhibitory concentration: 37100 nM
Compound 4: middle estimate off by 1.5-fold (0.17 log units), on the low side; the range from low to high includes it.
By their numbers in this assay, from the lowest: compounds 2, 3 and 4 (each within the scatter of the next). At a limit, above all of these: compound 1.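

In this assay, for the compounds shown here, this is the first exchange made on the chain itself: isopropyl in place of propyl on a double-bonded chain carbon bound to a double-bonded chain carbon gives a 1.4-fold higher number from compound 3 to compound 4 (0.14 log units; within the scatter), so pent-1-en-1-yl and 3-methylbut-1-en-1-yl cannot be told apart here with 6-methoxypyridin-3-yl on the nitrogen. With the 3-methylbut-1-en-1-yl chain held fixed, 6-methoxypyridin-3-yl in place of 3-methoxyphenyl on a nitrogen on an aromatic ring gives a 1.7-fold higher number from compound 2 to compound 4 (0.23 log units; within the scatter), so these two groups cannot be separated either. The exchange of 1-methyl-1H-pyrazol-3-yl for 6-methoxypyridin-3-yl on that nitrogen gives an at least 1.3-fold lower number from compound 1 to compound 4 (0.12 log units; that floor lies within the scatter), a step that rests on a limit and ranks neither compound: the limit of > 50000 nM in this assay, at which 1 of the 4 values shown sits.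

As far as these compounds go, it remains open whether any group on this chain would move the number beyond the scatter, for example a dimethylamino group in place of isopropyl, or a longer chain. From the compounds shown here alone, it is also open whether a different group on the aromatic ring on the nitrogen, such as a carboxylic acid in place of methoxy, would change the reading.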